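This account rests on a few compounds, and the source may have more. Where it says the series, first, only, none or still open, it means among the compounds named here.

Compound 2 `COc1ccc(NCN2C(=O)c3cccc(N)c3C2=O)cc1` gives 95.6% in an assay on isolated protein for inhibition of ribosomal protein S6 kinase alpha-2 (Homo sapiens), read by fluorescence, with a stated time of 20 min, tested at 10 uM; on this read-out higher numbers stand for more inhibition at the one concentration tested (going by the name of the read-out) and lower numbers for less inhibition; compound 1 `COc1ccc(NCN2C(=O)c3ccccc3C2=O)cc1` gives 97.2%, and the two sit within the scatter of one another, as a number 1.6 percentage points lower from compound 1 to compound 2 (within the scatter) shows. Compound 3 `COc1ccc(NCN2C(=O)c3cccc(NC(=O)c4ccccc4)c3C2=O)cc1` carries benzoyl in place of hydrogen on a nitrogen on an aromatic ring. Among the measured compounds shown here, the only measured step concerns the amino group itself, not a substituent on it, so no measured step bears directly on the benzoyl. With both measured compounds near the top of the read-out, the expected step of a number 7.6 percentage points lower from compound 2 to compound 3 (within the scatter) is small, with more room downward than upward. Compound 3 is estimated at 88%, between 62% and 99%.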

Compound 3, a percentage reported as inhibition, at one concentration (the size of the read-out at that concentration, not a potency): 99.5%
Estimate against measurement, compound 3: 11.5 percentage points below; measured number above the stated range.
By their numbers in this assay, from the lowest: compounds 2, 1 and 3 (each within the scatter of the next).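

On a nitrogen on an aromatic ring, benzoyl in place of hydrogen leaves the read-out in this assay within the scatter (a number 3.9 percentage points higher from compound 2 to compound 3 (within the scatter)). Counted from the unsubstituted core, the whole benzamido group also stays within it (a number 2.3 percentage points higher from compound 1 to compound 3 (within the scatter)), so this place accepts a six-membered aromatic ring carried on a carbonyl, which the amino step alone did not show. Nothing available explains this result. With a single concentration and all steps within the scatter, no order of potency can be read. Open, on these data alone, is how acetyl, a longer chain on that nitrogen, or a carboxylic acid on the benzoyl ring would read.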